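The source may report more compounds than this note shows. Statements on the series, on what has been measured and on what is new or still open speak of the compounds shown alone.

Compound 1 `COc1ccc(/C=C/C(=O)Nc2nc3ccccc3s2)cc1`: 435 umol/kg
Compound 2 `COc1ccc(/C=C/C(=O)Nc2nc3ccc(C)cc3s2)cc1`: 209 umol/kg
Compound 3 `O=C(/C=C/c1ccc(Cl)cc1)Nc1nc2ccc(Cl)cc2s1`: 204 umol/kg

Of the compounds shown here, three have been measured in a functional assay on the whole organism (Hindlimb, strain albino) with Mus musculus as the target, in the maximal electroshock model, with a stated time of 0.5 h; a higher number here means that more compound is needed for the effect, a lower number that less compound is needed. In this assay compound 3 gives 204 umol/kg, the lowest of the three numbers, though compound 2 gives 209 umol/kg and the two lie within the scatter of each other, so no order between them can be claimed. Compound 1 gives 435 umol/kg, a higher number than compound 3 by more than the scatter.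

Compound 4 `COc1ccc(/C=C/C(=O)Nc2nc3ccc(Cl)cc3s2)cc1` has not yet been measured. It differs from compound 3 in one place: methoxy in place of chloro on an aromatic carbon. Within the data shown here, the only measured step, a 2.1-fold lower number from compound 1 to compound 2 (0.32 log units; beyond the scatter), concerns a different change elsewhere in the shared core, methyl in place of hydrogen on an aromatic carbon, and says nothing about exchanging chloro for methoxy. Compounds 1 and 2 carry the methoxy that compound 4 gains, while compound 3 carries the chloro it loses, but in each pairing the core also differs, so no clean comparison exists. Among the measured compounds shown here, with no step that bears on the change, a small move in either direction, or none beyond the scatter, is expected. Compound 4 is therefore estimated at 230 umol/kg, with a range from 120 umol/kg to 450 umol/kg. This estimate means an expected step of a 1.1-fold higher number from compound 3 to compound 4 (0.05 log units; within the scatter).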

Compound 4, dose for half-maximal effect: 259 umol/kg
Compound 4: middle estimate off by 1.1-fold (0.05 log units), on the low side, and the stated range covers the measured number.
By their numbers in this assay, from the lowest: compounds 3, 2, 4 and 1 (each within the scatter of the next, the first and the last beyond it).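

In this assay, methoxy in place of chloro on this aromatic carbon, para to a large group, gives a 1.3-fold higher number from compound 3 to compound 4 (0.10 log units; within the scatter), so with chloro on the shared core, the two groups cannot be told apart at this place. The other place that varies on the core now has three groups to compare: chloro in place of methyl gives a 1.2-fold higher number from compound 2 to compound 4 (0.09 log units; within the scatter), and chloro in place of hydrogen gives a 1.7-fold lower number from compound 1 to compound 4 (0.23 log units; within the scatter), so neither chloro step can be read as a real difference, whereas the methyl step, a 2.1-fold lower number from compound 1 to compound 2 (0.32 log units; beyond the scatter), lies beyond the scatter. No accompanying measurement offers an explanation for these results.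

On these data alone, only chloro and methoxy are compared at the para place, so it remains open whether an amine, a carboxylic acid or a longer chain there would shift the number beyond the scatter. Among these compounds, this exchange has also been seen only with chloro on the core, leaving open whether it would give a similar result with hydrogen or methyl there.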